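Removing One Methoxy Group on Two Related Cores

A few compounds are considered here, and "the series" means these few. Any claim that something is new, unique, unknown or untested is made for them only; others in the source may bear on it.

Measured in a functional assay on SN12C cells (Homo sapiens) for inhibition, read by sulforhodamine B assay, with a stated time of 48 h; a lower number here means that less compound is tolerated, a higher number that more compound is tolerated:
Compound 1 `COc1cc(-c2cc(/C=C/C(=O)c3ccc(N)cc3)[nH]n2)cc(OC)c1OC`: 13400 nM
Compound 2 `COc1ccc(-c2cc(/C=C/C(=O)c3ccc(N)cc3)[nH]n2)cc1OC`: 41300 nM
Compound 3 `COc1cc(C(=O)/C=C/c2cc(-c3cc(OC)c(OC)c(OC)c3)n[nH]2)cc(OC)c1OC`: 5990 nM

Compound 3 holds the lowest of the three numbers. How its core differs from the core of compound 1 is not broken down here. Between compound 1 and compound 2 the change is hydrogen in place of methoxy on an aromatic carbon, and it gave a 3.1-fold higher number from compound 1 to compound 2 (0.49 log units; beyond the scatter) in this assay.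

Compound 4 `COc1ccc(-c2cc(/C=C/C(=O)c3cc(OC)c(OC)c(OC)c3)[nH]n2)cc1OC` arises from compound 3 by the same change, (hydrogen in place of methoxy on an aromatic carbon), at a place described in the same words. Among the compounds with values here, on compound 3 the step is expected to be a 3.0-fold higher number from compound 3 to compound 4 (0.48 log units; beyond the scatter) in this assay, resting on the single earlier step, the one from compound 1 to compound 2, which gave a 3.1-fold higher number from compound 1 to compound 2 (0.49 log units; beyond the scatter). Compound 4 is therefore estimated at 18000 nM, with a likely range from 8000 nM to 40000 nM.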

Compound 4, concentration lethal to 50% of the cells: 8260 nM
The estimate for compound 4 lay 2.2-fold (0.34 log units) above the measured number; measured number inside the range.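

In this assay, replacing the methoxy group with hydrogen on the core of compound 3 gave a 1.4-fold higher number from compound 3 to compound 4 (0.14 log units; within the scatter), a step too small to separate the two compounds. Within the data shown here, the two steps differ in whether they clear the scatter, yet the gap between them does not clear it: the same change on two cores in this assay, a 3.1-fold higher number (0.49 log units; beyond the scatter) from compound 1 to compound 2 and a 1.4-fold higher number (0.14 log units; within the scatter) from compound 3 to compound 4, 2.2-fold (0.35 log units) apart, within the scatter of two such steps This shows that the two results are compatible with one shared effect of the change across these two cores, but with only two steps it does not establish a common size or show that the change would carry to any other core.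

The compounds shown leave open what a hydroxyl group, a fluorine or a longer ethoxy chain would do in place of that methoxy group.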